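The source may hold more compounds than are shown below. What is called first, only, known or untested is meant among the compounds shown, and "the series" means these compounds.

Compound 3 `COc1ccccc1NC(=O)Nc1cccc(CNc2ncnc3cc(OC)c(OC)cc23)c1` stands lowest of the two numbers reported in a functional assay on MGC-803 cells (Homo sapiens) for antiproliferative activity, read by MTT assay; a higher number here means a weaker inhibitor, a lower number a stronger inhibitor: compound 3 gives 7710 nM. Its nearest neighbour is compound 1 `O=C(Nc1cccc(Cl)c1)Nc1cccc(CNc2ncnc3ccccc23)c1`, which in this assay gives 19200 nM. Compound 2 `O=C(Nc1cccc(CNc2ncnc3ccccc23)c1)Nc1cccc(C(F)(F)F)c1` in this assay gives > 50000 nM, which is a limit of the assay and not a number. Compound 4 `COc1cc2ncnc(NCc3cccc(NC(=O)Nc4ccccc4Cl)c3)c2cc1OC` differs from compound 3 by chloro in place of methoxy on an aromatic carbon. Within the data shown here, no measured step exchanges methoxy for chloro at that place; the only measured step, an at least 2.6-fold higher number from compound 1 to compound 2 (0.41 log units; beyond the scatter), concerns a different exchange of substituents on the terminal ring. Compound 4 is therefore expected to move by about a 1.3-fold higher number from compound 3 to compound 4 (0.11 log units; within the scatter) in this assay, a shift within the scatter. The estimate for compound 4 in this assay is 10000 nM, with a range from 4000 nM to 30000 nM.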

Compound 4, half-maximal inhibitory concentration: 30200 nM
Compound 4: middle estimate off by 3.0-fold (0.48 log units), on the low side, and the stated range ends below it.
By their numbers in this assay, from the lowest: compound 3; then compounds 1 and 4 (each within the scatter of the next). At a limit, above all of these: compound 2.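

In this assay, chloro in place of methoxy on this aromatic carbon, ortho to a large group, gives a 3.9-fold higher number from compound 3 to compound 4 (0.59 log units; beyond the scatter). Among these compounds, this is the only measured step at this place, and it shows that the 2-methoxyphenyl and 2-chlorophenyl groups are not interchangeable here, since this one exchange moves the number beyond the scatter. Nothing measured here bears on the cause of this step. Going by these compounds, what a fluoro, methyl or amine at this place would give remains open, as does whether the same exchange would act alike on the core of compound 1.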